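This account rests on a few compounds, and the source may have more. Where it says the series, first, only, none or still open, it means among the compounds named here.

Cytotoxicity here is read in a functional assay on SK-MEL-2 cells (Homo sapiens) for cytotoxicity, read by sulforhodamine B assay, with a stated time of 48 h; on this read-out lower numbers stand for higher toxicity in this test and higher numbers for lower toxicity in this test. Compound 2 `ClCc1cccc(Cn2cnc3c(Cl)nc(Cl)nc32)c1` is the only one of the three measured compounds that yields a number: in this assay compound 2 gives 10000 nM. The other two values are limits of the assay. Compound 1 `ClCc1ccc(Cn2cnc3c(Cl)ncnc32)cc1` gives a limit in this assay, > 100000 nM. Compound 3 `ClCc1ccccc1Cn1cnc2nc(Cl)nc(Cl)c21` likewise gives a limit in this assay, > 100000 nM. Compound 4 `Nc1nc(Cl)c2ncn(Cc3cccc(CCl)c3)c2n1` has not yet been measured; it differs from compound 2 by amino in place of chloro on an aromatic carbon. Among the measured compounds shown here, no step between two measured compounds is available to guide the expectation, so only a modest step towards lower toxicity, or none beyond the scatter, is expected, with wide uncertainty. The expected step is a 1.5-fold higher number from compound 2 to compound 4 (0.18 log units; within the scatter). For compound 4 the estimate in this assay is 15000 nM, ranging from 4000 nM to 60000 nM.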

Compound 4, concentration lethal to 50% of the cells: > 100000 nM
Compound 4 gave a limit, no number; the forecaster's own chance of this, stated with the estimate: 25%; middle value at least 6.6-fold (0.82 log units) away from the limit.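

Amino in place of chloro, on the aromatic carbon between two ring nitrogen atoms, gives an at least 10-fold higher number from compound 2 to compound 4 (1.00 log units; beyond the scatter) in this assay and is the first step that can be read in this set. Among the compounds shown here, this single change at this position is enough to take compound 2, the only compound with a number, to a limit. Compound 4 gives a limit rather than a number, so the step has a known minimum but no known full size because of where the values stop: the limit of > 100000 nM in this assay, at which 3 of the 4 values shown sit.

Going by these compounds, whether a methoxy or a dimethylamino group on this carbon would keep a number in this assay or also reach the limit stays open.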